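The source may report more compounds than this note shows. Statements on the series, on what has been measured and on what is new or still open speak of the compounds shown alone.

Compound 1 `CNC(=O)/C=C1/COc2cc(OS(=O)(=O)c3ccccc3)ccc21`: 34 nM
Compound 2 `CNC(=O)/C=C1/COc2cc(OS(=O)(=O)c3ccc(C#N)cc3)ccc21`: 45 nM

In an assay (strain Sprague-Dawley) for inhibition of Amine oxidase [flavin-containing] A (Rattus norvegicus), read by spectrophotometry, with a stated time of 5 min (on this read-out lower numbers stand for stronger inhibition and higher numbers for weaker inhibition), compound 1 gives the lowest of the two numbers, with compound 2 nearest at a 1.3-fold higher number from compound 1 to compound 2 (0.12 log units; within the scatter). Compound 3 `CNC(=O)/C=C1/COc2c1ccc(OS(=O)(=O)c1ccccc1)c2C` differs from compound 1 by methyl in place of hydrogen on an aromatic carbon. Among the measured compounds shown here, the single measured step concerns a different ring and a different group, so it bears only loosely on this change, showing merely that one substitution on this core stayed within the scatter. One therefore expects no step beyond the scatter in this assay for compound 3, estimated at 45 nM with a range of 15 nM to 140 nM. The expected step is a 1.3-fold higher number from compound 1 to compound 3 (0.12 log units; within the scatter).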

Compound 3, half-maximal inhibitory concentration: 9.8 nM
Estimate against measurement, compound 3: 4.6-fold (0.66 log units) above; measured number below the stated range.
By their numbers in this assay, from the lowest: compound 3; then compounds 1 and 2 (each within the scatter of the next).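

In this assay, methyl in place of hydrogen on this aromatic carbon, ortho to a fused ring and ortho to a large group, gives a 3.5-fold lower number from compound 1 to compound 3 (0.54 log units; beyond the scatter), so a single added carbon at this position of the shared core moves the number beyond the scatter. Among the compounds shown here, compound 3 is the only compound here whose step from compound 1 does so. Nothing available bears on the reason for this step. Going by these compounds, whether an ethyl group, a methoxy group or a chlorine atom at this carbon would give a similar step remains open. So does whether the methyl step holds alongside the nitrile of compound 2.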